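The compounds below may be only part of what the source reports. "The series", "measured", "known", "first", "only" and "open" are said of these compounds alone.

Measured so far in an assay on cells for inhibition of Ectonucleotide pyrophosphatase/phosphodiesterase family member 1 (Homo sapiens), with a stated time of 60 min; a lower number here means a stronger inhibitor, a higher number a weaker inhibitor:
compound 1 `COc1cc2nc(/C=C/c3ccccc3)nc(N3CCC(CCNS(N)(=O)=O)CC3)c2cc1OC` — 1840 nM
compound 2 `COc1cc2nc(/C=C/c3ccccn3)nc(N3CCC(CCNS(N)(=O)=O)CC3)c2cc1OC` — 71 nM
compound 3 `COc1cc2nc(/C=C/c3cccnc3)nc(N3CCC(CCNS(N)(=O)=O)CC3)c2cc1OC` — 58 nM

Compound 3 holds the lowest number in this assay, with compound 2 within the scatter of it and compound 1 far beyond it (a 32-fold lower number from compound 1 to compound 3 (1.50 log units; beyond the scatter)). Compound 4 `COc1cc2nc(/C=C/c3ccncc3)nc(N3CCC(CCNS(N)(=O)=O)CC3)c2cc1OC` differs from compound 3 by pyridin-4-yl in place of pyridin-3-yl on a double-bonded chain carbon bound to a double-bonded chain carbon. Among the measured compounds shown here, two steps bear on this. Replacing phenyl by either pyridyl was large: a 26-fold lower number from compound 1 to compound 2 (1.41 log units; beyond the scatter) and a 32-fold lower number from compound 1 to compound 3 (1.50 log units; beyond the scatter). Exchanging one pyridyl for another, however, stayed within the scatter: a 1.2-fold lower number from compound 2 to compound 3 (0.09 log units; within the scatter). A third pyridyl is therefore expected to behave like the other two, giving a step of a 1.0-fold higher number from compound 3 to compound 4 (0.01 log units; within the scatter), none beyond the scatter. Compound 4 is estimated at 60 nM in this assay, with a range from 30 nM to 130 nM.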

Compound 4, inhibition constant: 218 nM
For compound 4 the middle estimate is 3.6-fold (0.56 log units) below the measured one; measured number above the stated range.
By their numbers in this assay, from the lowest: compounds 3 and 2 (each within the scatter of the next); then compound 4; then compound 1.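

The position of the ring nitrogen matters at this place after all: pyridin-4-yl separates from pyridin-3-yl (a 3.8-fold higher number from compound 3 to compound 4 (0.58 log units; beyond the scatter)) and from pyridin-2-yl (a 3.1-fold higher number from compound 2 to compound 4 (0.49 log units; beyond the scatter)), while those two remain within the scatter of each other. Pyridin-4-yl still improves on phenyl, though by a smaller step (an 8.4-fold lower number from compound 1 to compound 4 (0.93 log units; beyond the scatter)). Nothing available accounts for this difference among the pyridyl groups.

Open, from the compounds shown here alone, is whether an amine or methoxy group on the pyridin-3-yl ring keeps the number. Also open, going by these compounds, is how a pyrimidine ring or a longer chain would compare here.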